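Amine substituent swap on the shared core

This account rests on a few compounds, and the source may have more. Where it says the series, first, only, none or still open, it means among the compounds named here.

In a functional assay on U2OS cells (Homo sapiens) for antiproliferative activity, read by MTT assay, with a stated time of 72 h (on this read-out higher numbers stand for weaker inhibition and lower numbers for stronger inhibition), compound 1 `NC1=C(C(=O)c2ccccc2)C(c2ccc(Br)cc2)N(CCCn2ccnc2)C1=O` gives 149000 nM. Compound 2 `Cc1ccc(NC2=C(C(=O)c3ccccc3)C(c3ccc(Br)cc3)N(CCCn3ccnc3)C2=O)cc1` gives 24100 nM, the second highest of the three numbers; compound 3 `O=C(C1=C(Nc2ccc(OC(F)(F)F)cc2)C(=O)N(CCCn2ccnc2)C1c1ccc(Br)cc1)c1ccccc1` gives 11500 nM, and a 2.1-fold lower number from compound 2 to compound 3 (0.32 log units; beyond the scatter). Against hydrogen, a 6.2-fold lower number from compound 1 to compound 2 (0.79 log units; beyond the scatter) and a 13-fold lower number from compound 1 to compound 3 (1.11 log units; beyond the scatter), so a group on this nitrogen lowers the number. Compound 4 `O=C(C1=C(NCc2ccccc2)C(=O)N(CCCn2ccnc2)C1c1ccc(Br)cc1)c1ccccc1` is not yet measured; (benzyl in place of 4-methylphenyl on an amine nitrogen). Within the data shown here, no measured step exchanges an aryl group for a benzyl group on this nitrogen, so the measured steps bear only indirectly: compound 4 keeps a substituent there, which argues against a return towards compound 1. The expected step of a 1.5-fold higher number from compound 2 to compound 4 (0.16 log units; within the scatter) is therefore small, probably within the scatter. Compound 4 is estimated at 35000 nM, with a range from 12000 nM to 100000 nM.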

Compound 4, half-maximal inhibitory concentration: 32500 nM
Beside the measured number, compound 4's estimate is 1.1-fold (0.03 log units) above it, within the range that was stated.
By their numbers in this assay, from the lowest: compound 3; then compounds 2 and 4 (each within the scatter of the next); then compound 1.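

Benzyl on this amine nitrogen reads level with 4-methylphenyl in this assay (a 1.3-fold higher number from compound 2 to compound 4 (0.13 log units; within the scatter)), so an aromatic ring joined directly to the nitrogen is not required for a number in this range. Benzyl also retains a gain over hydrogen (a 4.6-fold lower number from compound 1 to compound 4 (0.66 log units; beyond the scatter)) but stays apart from the 4-(trifluoromethoxy)phenyl compound (a 2.8-fold higher number from compound 3 to compound 4 (0.45 log units; beyond the scatter)). No measured evidence accounts for these steps.

Open, from the compounds shown here alone, is whether trifluoromethoxy on the benzyl ring would lower the number as it does on the directly attached phenyl ring. Also open, going by these compounds, is how a longer phenethyl chain on this nitrogen would read.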